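The compounds below may be only part of what the source reports. "The series", "measured", "known", "first", "only" and "open" are said of these compounds alone.

Measured so far in a functional assay on HepG2 cells (Homo sapiens) for inhibition, read by MTT assay, with a stated time of 48 h, tested at 10 uM; on this read-out higher numbers stand for more inhibition of growth at the one concentration tested and lower numbers for less inhibition of growth:
compound 1 `COc1ccc(C(=O)/C=C/c2ccc(OCc3cn(Cc4cccc(F)c4)nn3)cc2)cc1`, 22%
compound 2 `O=C(/C=C/c1ccc(OCc2cn(Cc3ccccc3)nn2)cc1)c1ccc([N+](=O)[O-])cc1`, "not active" (no number reported)
compound 3 `O=C(/C=C/c1ccc(OCc2cn(Cc3ccccc3Br)nn2)cc1)c1ccc([N+](=O)[O-])cc1`, 32%

In this assay the numbers for compound 3 and compound 1 lie within the usual scatter of each other, and compound 2 is reported only as not active, without a number. Compound 4 `O=C(/C=C/c1ccc(OCc2cn(Cc3cccc(F)c3)nn2)cc1)c1ccc([N+](=O)[O-])cc1` is the next entry for this assay. Its difference from compound 3 is 3-fluorophenyl in place of 2-bromophenyl on a saturated chain carbon bound to an aromatic nitrogen. Within the data shown here, no measured pair shows this exact change alone. Compound 2, differing from compound 4 only in the group on that saturated chain carbon, gave no number in this assay, while compound 1, carrying the same 3-fluorophenyl group but differing elsewhere, gave 22%. A modest downward step is therefore expected, a number 12 percentage points lower from compound 3 to compound 4 (beyond the scatter), possibly no larger than the scatter. Compound 4 is estimated at 20% in this assay, in the range 0% to 38%.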

Compound 4, percent growth inhibition at one concentration: 43%
Compound 4: the middle estimate sits 23 percentage points below what was measured; measured number above the stated range.
By their numbers in this assay, from the lowest: compounds 1 and 3 (each within the scatter of the next); then compound 4.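

In this assay, among these compounds, 3-fluorophenyl in place of 2-bromophenyl on a saturated chain carbon bound to an aromatic nitrogen gives a number 11 percentage points higher from compound 3 to compound 4 (beyond the scatter), the first reading of a single change at this position. With 3-fluorophenyl held, nitro in place of methoxy on an aromatic carbon gives a number 21 percentage points higher from compound 1 to compound 4 (beyond the scatter). Nothing measured on hand gives a reason for either step.

The change at the first position swaps halogen and ring position together, and the compounds shown do not separate the two. Going by these compounds, how an amine or a carboxylic acid in place of nitro on that aromatic carbon would read also stays open.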